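The source may hold more compounds than are shown below. What is called first, only, known or untested is meant among the compounds shown, and "the series" means these compounds.

Of the compounds shown here, three have been measured in an assay on Sf9 cells for inhibition of protein deacetylase HDAC6 (Homo sapiens), read by fluorescence, with a stated time of 40 min, tested at 100 nM; a higher number here means more inhibition at the concentration tested (going by the name of the read-out), a lower number less inhibition. Compound 1 `O=C(NO)c1ccc(NCc2nc(-c3ccccc3)nn2-c2cccc(Cl)c2)cc1` gives 62.3% in this assay, and compound 2 `COc1ccc(-n2nc(-c3ccccc3)nc2CNc2ccc(C(=O)NO)cc2)cc1` gives 63.4%. For the measured compounds named here, the only measured step, a number 1.1 percentage points higher from compound 1 to compound 2 (within the scatter), changes a group on an aromatic nitrogen and leaves the carbonyl end untouched. Compound 3 `O=C(O)c1ccc(NCc2nc(-c3ccccc3)nn2-c2ccccc2)cc1` gives -0.4%, the lowest of the three numbers; compounds 1 and 2 stand beyond the scatter above it, and both differ from compound 3 in the group on the carbonyl carbon. Compound 4 `NNC(=O)c1ccc(NCc2nc(-c3ccccc3)nn2-c2ccccc2)cc1` has not yet been measured. It differs from compound 3 by aminoamino in place of hydroxy on a carbonyl carbon. Going by the values given here, no measured step changes the group on the carbonyl carbon, so the step from compound 1 to compound 2 offers no guide here; the numbers show only that compound 3, with hydroxy on the carbonyl carbon, gives almost no inhibition, while the two compounds with a different group there give much more. The step from compound 3 to compound 4 is therefore expected to be a number 35.4 percentage points higher from compound 3 to compound 4 (beyond the scatter), upward but very uncertain. Compound 4 is expected to give about 35%, somewhere between 0% and 70%.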

Compound 4, a percentage reported as inhibition, at one concentration (the size of the read-out at that concentration, not a potency): 10%
Compound 4: the middle estimate sits 25 percentage points above what was measured, within the range that was stated.
By their numbers in this assay, from the lowest: compound 3; then compound 4; then compounds 1 and 2 (each within the scatter of the next).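

In this assay replacing hydroxy with aminoamino on the carbonyl carbon, with the rest of the molecule unchanged, gives a number 10.4 percentage points higher from compound 3 to compound 4 (beyond the scatter). For the compounds shown here, this is the first direct reading of a change at this position: it shows that the position responds to the swap, but the response is modest, with compound 4 reaching only 10% at the concentration tested. Replacing hydroxy here therefore does not by itself ensure strong inhibition, and no measurement available explains the size of this step.

Compounds 1 and 2 differ from compound 4 in more than one place, so their numbers cannot isolate the effect of the group on the carbonyl carbon. Also open, from the compounds shown here alone, is how an amino group or a methoxy group on that carbon would read.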